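This account rests on a few compounds, and the source may have more. Where it says the series, first, only, none or still open, it means among the compounds named here.

Compound 1 `COc1ccccc1CNc1ncnc2c1ncn2C1CCCCO1`: in an ADME assay on MCF7 cells (Homo sapiens) for cytotoxicity, with a stated time of 72 h (on this read-out higher numbers stand for weaker inhibition and lower numbers for stronger inhibition), compound 1 gives > 100000 nM, which is a limit of the assay rather than a number.
Compound 2 `COc1ccc(OC)c(CNc2ncnc3c2ncn3C2CCCCO2)c1`: in this assay compound 2 gives 25400 nM.
Compound 3 `COc1ccc(CNc2ncnc3c2ncn3C2CCCCO2)cc1OC`: in this assay compound 3 gives > 100000 nM, which is again a limit of the assay.

Compound 1 and compound 2 differ in a single place: methoxy in place of hydrogen on an aromatic carbon. That change produced an at least 3.9-fold lower number from compound 1 to compound 2 (0.59 log units; beyond the scatter). The true size of this step is known only as a lower bound, because compound 1 sits at the limit of > 100000 nM in this assay, at which 2 of the 3 values shown sit.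

Compound 3 carries the same core as compound 1 but differs from it in more than one place; the difference between the two cores is not broken down here. Compound 4 `COc1ccc(CNc2ncnc3c2ncn3C2CCCCO2)c(OC)c1OC` has not yet been measured. It differs from compound 3 by methoxy in place of hydrogen on an aromatic carbon. The surroundings are not identical: in compound 2 the new methoxy sits meta to a large group and para to a methoxy group, whereas in compound 4 it sits ortho to a large group, ortho to a methoxy group and meta to a methoxy group. This is therefore the same kind of change, not the same change.

The expectation for the new compound rests on an at least 3.9-fold lower number from compound 1 to compound 2 (0.59 log units; beyond the scatter), though the starting point for compound 3 is itself only a limit. The expected step is an at least 2.0-fold lower number from compound 3 to compound 4 (0.30 log units; that floor lies within the scatter). Compound 4 is estimated at 50000 nM, with a likely range from 15000 nM to 150000 nM, and a real chance that this assay again reports only a limit.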

Compound 4, half-maximal inhibitory concentration: > 37500 nM
Compound 4 was reported as a limit; the forecaster's own chance of this, stated with the estimate: 40%; the middle value is on the limit's open side.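

Compound 3 and compound 4 are both reported only as limits in this assay, and the step between them cannot be read. The compounds shown leave open whether methoxy in place of hydrogen, placed here ortho to a large group and ortho to a methoxy group, changes the number in this assay at all, as the same kind of change did between compound 1 and compound 2.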